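Ethoxy for Isopropyl Across Two Double-Bond Geometries

The compounds below may be only part of what the source reports. "The series", "measured", "known", "first", "only" and "open" are said of these compounds alone.

Compound 1 `COc1cc(/C=C/c2ccc(C(C)C)cc2)cc(OC)c1OC` and compound 3 `COc1cc(/C=C\c2ccc(C(C)C)cc2)cc(OC)c1OC` are built from the same atoms and bonds: the two compounds have the same atoms and bonds and differ only in configuration as drawn: 1 of 1 stereo elements differ; a double bond is drawn E in compound 1 and Z in compound 3. In a functional assay on A549 cells (Homo sapiens) for cytotoxicity (a higher number here means that more compound is needed for the effect, a lower number that less compound is needed), compound 1 gives 9.8 uM, and compound 3 gives 6.6 uM, a gap described as a 1.5-fold lower number from compound 1 to compound 3 (0.17 log units; within the scatter). Compound 2 `CCOc1ccc(/C=C/c2cc(OC)c(OC)c(OC)c2)cc1` differs from compound 1 in one place, (ethoxy in place of isopropyl on an aromatic carbon); in this assay compound 2 gives 1.7 uM, which is a 5.8-fold lower number from compound 1 to compound 2 (0.76 log units; beyond the scatter). Compound 4 `CCOc1ccc(/C=C\c2cc(OC)c(OC)c(OC)c2)cc1` has not yet been measured. It differs from compound 3 by the same change, (ethoxy in place of isopropyl on an aromatic carbon), made in the same place on the other drawn geometry of the double bond. The step expected here is a 5.5-fold lower number from compound 3 to compound 4 (0.74 log units; beyond the scatter), resting on the measured step of a 5.8-fold lower number from compound 1 to compound 2 (0.76 log units; beyond the scatter) and on the small gap a 1.5-fold lower number from compound 1 to compound 3 (0.17 log units; within the scatter). Compound 4 is therefore expected to give 1.2 uM in this assay, with a likely range from 0.5 uM to 3.5 uM.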

Compound 4, concentration for half-maximal effect: 1.6 uM
The estimate for compound 4 lay 1.3-fold (0.12 log units) below the measured number, and the stated range covers the measured number.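

On the core of compound 3, ethoxy in place of isopropyl gives a 4.1-fold lower number from compound 3 to compound 4 (0.62 log units; beyond the scatter) in this assay, and this step matches the earlier one on the core of compound 1: the same change on two cores in this assay, a 5.8-fold lower number (0.76 log units; beyond the scatter) from compound 1 to compound 2 and a 4.1-fold lower number (0.62 log units; beyond the scatter) from compound 3 to compound 4, 1.4-fold (0.15 log units) apart, within the scatter of two such steps. With ethoxy in place, the two drawn geometries of the double bond cannot be told apart in this assay, as a 1.1-fold lower number from compound 2 to compound 4 (0.03 log units; within the scatter) shows. These two cores differ only in that geometry, so the result shows the change carrying over between them, but not to a core that differs in its atoms or bonds, and it does not explain why the change has this effect.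

As far as these compounds go, it remains open how a longer chain such as butoxy, an amine or a carboxylic acid would behave in the same place. From the compounds shown here alone, it also remains open whether the same step would appear in cells other than A549.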